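The compounds below may be only part of what the source reports. "The series", "measured", "known", "first", "only" and "open" are said of these compounds alone.

Measured compounds:
- compound 1, `COc1cccc(/C=C2\CCC/C(=C\c3cc(Cl)cc(Cl)c3)C2=O)c1OC`: in a functional assay on HT-1080 cells (Homo sapiens) for cytotoxicity, read by MTT assay, with a stated time of 72 h (a higher number here means a weaker inhibitor, a lower number a stronger inhibitor), compound 1 gives 6100 nM
- compound 2, `COc1cccc(/C=C2\CCC/C(=C\c3ccc(O)c(Cl)c3)C2=O)c1OC`: compound 2 gives 14300 nM
- compound 3, `COc1ccc(/C=C2\CCC/C(=C\c3cc(Cl)cc(Cl)c3)C2=O)cc1OC`: compound 3 gives 3000 nM

Compound 1 and compound 2 share a core and differ by one change, (3-chloro-4-hydroxyphenyl in place of 3,5-dichlorophenyl on a double-bonded chain carbon bound to a double-bonded ring carbon); this change produced a 2.3-fold higher number from compound 1 to compound 2 (0.37 log units; beyond the scatter). Compound 3 carries the same atoms as compound 1 joined differently; the difference between the two cores is not broken down here, and compound 3 gives the lowest number of the three. Compound 4, `COc1ccc(/C=C2\CCC/C(=C\c3ccc(O)c(Cl)c3)C2=O)cc1OC`, has not yet been measured. It stands to compound 3 as compound 2 stands to compound 1: the change is 3-chloro-4-hydroxyphenyl in place of 3,5-dichlorophenyl on a double-bonded chain carbon bound to a double-bonded ring carbon, the same change at the same place. Among the compounds with values here, from compound 3 to compound 4 a step of a 2.3-fold higher number from compound 3 to compound 4 (0.36 log units; beyond the scatter) is expected, resting on the single earlier instance, a 2.3-fold higher number from compound 1 to compound 2 (0.37 log units; beyond the scatter). On that basis compound 4 is estimated at 6900 nM, with a likely range from 3500 nM to 14000 nM.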

Compound 4, half-maximal inhibitory concentration: 7600 nM
Compound 4: middle estimate off by 1.1-fold (0.04 log units), on the low side, and the stated range covers the measured number.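

In this assay, 3-chloro-4-hydroxyphenyl in place of 3,5-dichlorophenyl gives a 2.5-fold higher number from compound 3 to compound 4 (0.40 log units; beyond the scatter) and the step carries from one core to the other at much the same size: the same change on two cores in this assay, a 2.3-fold higher number (0.37 log units; beyond the scatter) from compound 1 to compound 2 and a 2.5-fold higher number (0.40 log units; beyond the scatter) from compound 3 to compound 4, 1.1-fold (0.03 log units) apart, within the scatter of two such steps. This agreement rests on two closely related cores, one pair of groups and one cell assay, and it does not show that the step would hold on a more distant core. Nor does it separate the loss of one chlorine from the gain of the hydroxyl, as both arrive in a single change.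

The compounds shown leave open how an amine or a carboxylic acid on this phenyl ring would compare. They also leave open whether the step survives when the methoxy groups of the other phenyl ring give way to longer alkoxy chains.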